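A Thiadiazolylsulfanyl Variant of a Weakly Active Pyrimidine

A few compounds are considered here, and "the series" means these few. Any claim that something is new, unique, unknown or untested is made for them only; others in the source may bear on it.

Measured compounds:
compound 1 `CCN1CCN(c2cc(C(F)(F)F)nc(SCc3ccc(C(F)(F)F)cc3)n2)CC1`: 22000 nM
compound 2 `CC(C)(C)OC(=O)N1CCN(c2cc(C(F)(F)F)nc(SCc3ccc(C(F)(F)F)cc3)n2)CC1`: > 50000 nM
compound 3 `FC(F)(F)c1ccc(CSc2nc(N3CCN(c4ncccn4)CC3)cc(C(F)(F)F)n2)cc1`: > 50000 nM

Among the compounds with values here, in a functional assay on MCF7 cells (Homo sapiens) for inhibition, read by MTT assay, with a stated time of 72 h (on this read-out lower numbers stand for stronger inhibition and higher numbers for weaker inhibition), compound 1 gives 22000 nM, the only actual number among the three results. The value of compound 2 in this assay is a limit of the assay and not a number. The value of compound 3 in this assay is likewise a limit. Both sit at the limit of > 50000 nM in this assay, at which 2 of the 3 values shown sit.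

Compound 4 `Cc1nnc(Sc2cc(C(F)(F)F)nc(SCc3ccc(C(F)(F)F)cc3)n2)s1` is the unmeasured member of the set. Compared with compound 1 it carries (5-methyl-1,3,4-thiadiazol-2-yl)sulfanyl in place of 4-ethylpiperazin-1-yl on an aromatic carbon.

The two measured steps change only the group on the piperazine nitrogen: an at least 2.2-fold higher number from compound 1 to compound 2 (0.35 log units; beyond the scatter) and an at least 2.2-fold higher number from compound 1 to compound 3 (0.35 log units; beyond the scatter). Neither step removes the piperazine, so they speak to compound 4 only loosely; they do show that every change made so far from compound 1 led to a weaker result, and compound 1 itself is already weak. The step from compound 1 to compound 4 is therefore expected to be small or to lean toward a weaker result, a 1.4-fold higher number from compound 1 to compound 4 (0.13 log units; within the scatter).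

For compound 4 in this assay an estimate of 30000 nM is expected, with a likely range from 10000 nM to 80000 nM.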

Compound 4, half-maximal inhibitory concentration: > 50000 nM
Compound 4 was reported as a limit; the forecaster's own chance of this, stated with the estimate: 45%; at least 1.6-fold (0.22 log units) between middle value and limit.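

In this assay compound 4 gives > 50000 nM, which is a limit of the assay and not a number. The earlier compounds shown here changed only the group on the piperazine nitrogen, while here the whole 4-ethylpiperazin-1-yl on this aromatic carbon gives way to (5-methyl-1,3,4-thiadiazol-2-yl)sulfanyl, and the result is an at least 2.2-fold higher number from compound 1 to compound 4 (0.35 log units; beyond the scatter). This shows that the modest activity of compound 1 does not survive this replacement of the piperazine itself, so that compound 1 remains the only one of the set with an actual number and compound 4 joins the other two at the ceiling: the limit of > 50000 nM in this assay, at which 3 of the 4 values shown sit.

The steps among compounds 2, 3 and 4 cannot be read, so nothing can be said about their order, or about whether the loss in compound 4 comes from the thiadiazole ring or from the sulfur that joins it to the core. Also open, on these data alone, is whether a different amine at this carbon, such as morpholine or an unsubstituted piperazine, or a longer chain in place of the ethyl on the piperazine nitrogen, would give a lower number than compound 1.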